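The source may hold more compounds than are shown below. What is called first, only, known or untested is meant among the compounds shown, and "the series" means these compounds.

Compound 2 `O=C(Nc1ccc(NCc2ccc(F)cc2)cc1Cl)c1cc(Cl)ccc1O` is the reference point. For the measured compounds named here, in an ADME assay on A549 cells (Homo sapiens) for cytotoxicity, read by resazurin assay, with a stated time of 48 h (a higher number here means that more compound is tolerated, a lower number that less compound is tolerated), compound 2 gives 54400 nM; no measured compound gives a higher number, although compound 3 `O=C(Nc1ccc(NCc2cc(F)cc(C(F)(F)F)c2)cc1Cl)c1cc(Cl)ccc1O` at 30900 nM lies within the usual scatter of it. Compound 1 `O=C(Nc1ccc(NCC2CC2)cc1Cl)c1cc(Cl)ccc1O` gives 14400 nM, and the change from it to compound 2 produced a 3.8-fold higher number from compound 1 to compound 2 (0.58 log units; beyond the scatter).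

Compound 4 `O=C(Nc1ccc(NCc2cccnc2Cl)cc1Cl)c1cc(Cl)ccc1O` is the next compound. Its change from compound 2 is 2-chloropyridin-3-yl in place of 4-fluorophenyl on a saturated chain carbon bound to a nitrogen on an aromatic ring.

Going by the values given here, only one measured step touches that place, and it swapped a cyclopropyl for an aromatic ring: a 3.8-fold higher number from compound 1 to compound 2 (0.58 log units; beyond the scatter). Among the compounds with values here, no measured step replaces one aromatic ring by another at that place; compound 2 and compound 3, which carry two differently substituted benzene-type rings there, give numbers within the scatter of one another. Going from one six-membered aromatic ring to another is therefore expected to move the number little, with no step beyond the scatter: a 1.2-fold lower number from compound 2 to compound 4 (0.08 log units; within the scatter). Compound 4 is estimated at 45000 nM, between 20000 nM and 100000 nM.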

Compound 4, half-maximal cytotoxic concentration: 101000 nM
Compound 4: the middle estimate sits 2.2-fold (0.35 log units) below what was measured, and the stated range ends below it.
By their numbers in this assay, from the lowest: compound 1; then compounds 3, 2 and 4 (each within the scatter of the next, the first and the last beyond it).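

In this assay, for the compounds shown here, this is the first replacement of one aromatic ring by another on a saturated chain carbon bound to a nitrogen on an aromatic ring, and it gives a 1.9-fold higher number from compound 2 to compound 4 (0.27 log units; within the scatter), so 2-chloropyridin-3-yl and 4-fluorophenyl cannot be told apart here. Measured against cyclopropyl, 2-chloropyridin-3-yl gives a 7.0-fold higher number from compound 1 to compound 4 (0.85 log units; beyond the scatter), which shows that a ring with a hetero atom can also stand clear of cyclopropyl, as 4-fluorophenyl does. Nothing available explains why the numbers fall as they do.

On these data alone, it remains open whether the chlorine or the ring nitrogen matters for this result, and how a plain pyridin-3-yl group would compare. As far as these compounds go, it is also open whether a ring is needed at all, or whether a longer chain or a chain ending in an amine would give similar numbers.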